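The source may report more compounds than this note shows. Statements on the series, on what has been measured and on what is new or still open speak of the compounds shown alone.

Working notes on the series. The three measured compounds are compound 1 `CN(CC[C@H](N)C(=O)O)C[C@H]1O[C@@H](n2cnc3c(N)ncnc32)[C@H](O)[C@@H]1O`, compound 2 `CC(C)N(CC[C@H](N)C(=O)O)C[C@H]1O[C@@H](n2cnc3c(N)ncnc32)[C@H](O)[C@@H]1O` and compound 3 `C#CCN(CC[C@H](N)C(=O)O)C[C@H]1O[C@@H](n2cnc3c(N)ncnc32)[C@H](O)[C@@H]1O`. In an assay for inhibition of tRNA (cytosine(38)-C(5))-methyltransferase (Homo sapiens), with a stated time of 5 min, tested at 100 uM (on this read-out lower numbers stand for less inhibition and higher numbers for more inhibition at the one concentration tested (going by the name of the read-out)), compound 1 gives 30.3%, compound 2 gives 44%, and compound 3 gives 72.2%, the highest of the three. The steps are a number 13.7 percentage points higher from compound 1 to compound 2 (beyond the scatter), a number 41.9 percentage points higher from compound 1 to compound 3 (beyond the scatter) and a number 28.2 percentage points higher from compound 2 to compound 3 (beyond the scatter). The next compound is compound 4 `CCC#CCN(CC[C@H](N)C(=O)O)C[C@H]1O[C@@H](n2cnc3c(N)ncnc32)[C@H](O)[C@@H]1O`, differing from compound 3 by ethyl in place of hydrogen on a triple-bonded carbon. Within the data shown here, no measured step alters the triple-bonded carbon itself; the steps above change the amine nitrogen substituent, so they bear only loosely. With compound 3 already high in this assay, an estimated step of a number 6.2 percentage points lower from compound 3 to compound 4 (within the scatter) is expected, within the scatter. Compound 4 is estimated at 66%, between 42% and 86%.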

Compound 4, a percentage reported as inhibition, at one concentration (the size of the read-out at that concentration, not a potency): 62.8%
Compound 4: the middle estimate sits 3.2 percentage points above what was measured; the range from low to high includes it.
By their numbers in this assay, from the lowest: compound 1; then compound 2; then compounds 4 and 3 (each within the scatter of the next).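

In this assay, among these compounds, the first change on the triple-bonded carbon itself, ethyl in place of hydrogen, leaves compound 3 and compound 4 unseparated (a number 9.4 percentage points lower from compound 3 to compound 4 (within the scatter)). The pent-2-yn-1-yl group still stands clear of the smaller amine nitrogen substituents (a number 18.8 percentage points higher from compound 2 to compound 4 (beyond the scatter); a number 32.5 percentage points higher from compound 1 to compound 4 (beyond the scatter)). Nothing available bears on the reason for these results.

Open, going by these compounds, is whether a longer chain, or an amine or a hydroxyl group, on the triple-bonded carbon would separate from compound 3 in this assay.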